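The source may hold more compounds than are shown below. What is called first, only, known or untested is meant among the compounds shown, and "the series" means these compounds.

Working notes on the ribosylated series.

Compound 2 `O=c1[nH]cnc2c1c(-c1ccccc1)cn2[C@@H]1O[C@H](CO)[C@@H](O)[C@H]1O` carries a phenyl on the shared core. In a functional assay on CCRF-CEM cells (Homo sapiens), read by MTT assay, with a stated time of 72 h (a lower number here means a stronger inhibitor, a higher number a weaker inhibitor), compound 2 gives only a limit, > 100000 nM. Compound 1 `O=c1[nH]cnc2c1c(-c1ccsc1)cn2[C@@H]1O[C@H](CO)[C@@H](O)[C@H]1O` differs from compound 2 by thiophen-3-yl in place of phenyl on an aromatic carbon, and in this assay compound 1 gives 14500 nM. The step is an at least 6.8-fold lower number from compound 2 to compound 1 (0.83 log units; beyond the scatter); because the starting point is the limit at which part of the set sits (the limit of > 100000 nM in this assay, at which 2 of the 3 values shown sit), only its lower bound is readable.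

Compound 3 `Nc1nc2c(c(-c3ccccc3)cn2[C@@H]2O[C@H](CO)[C@@H](O)[C@H]2O)c(=O)[nH]1` differs from compound 2 in the core, by amino in place of hydrogen on an aromatic carbon. In this assay compound 3 gives only a limit, > 100000 nM. The step is a step that the two limits leave unreadable from compound 2 to compound 3, so the two cores cannot be ranked against each other from these data.

Compound 4 `Nc1nc2c(c(-c3ccsc3)cn2[C@@H]2O[C@H](CO)[C@@H](O)[C@H]2O)c(=O)[nH]1` stands to compound 3 as compound 1 stands to compound 2: the change is thiophen-3-yl in place of phenyl on an aromatic carbon, the same change as before, at the same place. Going by these compounds, what is expected for compound 4 rests on one measured instance of this change, from compound 2 to compound 1 (an at least 6.8-fold lower number from compound 2 to compound 1 (0.83 log units; beyond the scatter)), and on compound 3 starting at a limit (> 100000 nM) whose true value is unknown. The step from compound 3 to compound 4 is therefore expected to be roughly an at least 2.8-fold lower number from compound 3 to compound 4 (0.45 log units; beyond the scatter), with wide uncertainty. Compound 4 is expected to give about 35000 nM in this assay, somewhere between 8000 nM and 150000 nM, and a second limit rather than a number is a real possibility.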

Compound 4, half-maximal inhibitory concentration: > 20000 nM
Compound 4 ended at the assay's limit; the forecaster's own chance of this, stated with the estimate: 35%; the middle value lies beyond the limit too.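

In this assay compound 4 gives only a limit, > 20000 nM. Among the compounds shown here, the steps between compounds that end at a limit cannot be read, so on the amino-bearing core the change of thiophen-3-yl in place of phenyl is neither confirmed nor refuted, and its only readable instance stays an at least 6.8-fold lower number from compound 2 to compound 1 (0.83 log units; beyond the scatter). Comparing the two thiophen-3-yl compounds, amino in place of hydrogen on an aromatic carbon gives an at least 1.3-fold higher number from compound 1 to compound 4 (0.13 log units; that floor lies within the scatter), which shows no separation beyond the scatter and does not show whether the two cores differ, so the result cannot say whether the change carries from one core to the other.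

The compounds shown leave open how a furan-3-yl or a thiophen-2-yl on the same aromatic carbon would read on either core, and so whether the readable step belongs to thiophen-3-yl alone. They also leave open what a methylamino or a methyl in place of the amino would give, and the amino step itself stays without a pair that has a number at both ends.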